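The source may hold more compounds than are shown below. What is called first, only, known or untested is meant among the compounds shown, and "the series" means these compounds.

Three measured compounds share one core. In a functional assay on MCF7 cells (Homo sapiens) for antiproliferative activity, read by MTT assay, with a stated time of 48 h (on this read-out lower numbers stand for stronger inhibition and higher numbers for weaker inhibition), compound 1 `O=C(/C=C/c1cccc(NC(=O)c2ccccc2Cl)c1)c1nc2ccccc2[nH]1` gives 4570 nM. In this assay compound 2 `O=C(Nc1cccc(/C=C/C(=O)c2nc3ccccc3[nH]2)c1)c1cccc(Cl)c1` gives 7840 nM. In this assay compound 3 `O=C(/C=C/c1cccc(NC(=O)c2ccccc2Br)c1)c1nc2ccccc2[nH]1` gives 4520 nM. Compound 2 stands at the highest of the three numbers, yet the step of a 1.7-fold higher number from compound 1 to compound 2 (0.23 log units; within the scatter) and the step of a 1.7-fold lower number from compound 2 to compound 3 (0.24 log units; within the scatter) are both within the scatter, as is a 1.0-fold lower number from compound 1 to compound 3 (0.00 log units; within the scatter). Compound 4 `Cc1ccc(S(=O)(=O)Nc2cccc(/C=C/C(=O)c3nc4ccccc4[nH]3)c2)cc1` differs from compound 2 in that ((4-methylphenyl)sulfonyl in place of (3-chlorophenyl)carbonyl on a nitrogen on an aromatic ring). Among the measured compounds shown here, none of the measured steps exchanges a carbonyl for a sulfonyl; each only varies the halogenated phenyl on the carbonyl carbon, so they offer no direct guide. A small step at most is expected, a 1.0-fold higher number from compound 2 to compound 4 (0.01 log units; within the scatter). Compound 4 is therefore estimated at 8000 nM, with a range from 2500 nM to 25000 nM.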

Compound 4, half-maximal inhibitory concentration: 3220 nM
Estimate against measurement, compound 4: 2.5-fold (0.40 log units) above; the measured number falls inside the stated range.
By their numbers in this assay, from the lowest: compounds 4, 3, 1 and 2 (each within the scatter of the next, the first and the last beyond it).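

In this assay, among the compounds shown here, (4-methylphenyl)sulfonyl on the nitrogen gives the first step at this position to pass the scatter (a 2.4-fold lower number from compound 2 to compound 4 (0.39 log units; beyond the scatter)), though only against the 3-chlorophenyl amide. Against the other two amides the exchange stays within the scatter (a 1.4-fold lower number from compound 3 to compound 4 (0.15 log units; within the scatter); a 1.4-fold lower number from compound 1 to compound 4 (0.15 log units; within the scatter)), so the sulfonyl linkage is accepted here with no loss relative to any of the three compounds. The compounds shown do not separate the sulfonyl from the 4-methyl group, and how a (4-methylphenyl)carbonyl, or a phenylsulfonyl bearing an amine or a carboxylic acid, would read stays open. No available evidence bears on this result.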